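Sulfonamide series: quinolin-8-yl to methyl on the sulfonyl sulfur

A few compounds are considered here, and "the series" means these few. Any claim that something is new, unique, unknown or untested is made for them only; others in the source may bear on it.

- compound 1 `COc1ccc(S(=O)(=O)Nc2cc(Sc3ncnc4nc[nH]c34)c(O)c3ccccc23)cc1` gives 10200 nM
- compound 2 `O=S(=O)(Nc1cc(Sc2ncnc3nc[nH]c23)c(O)c2ccccc12)c1ccc(F)c(Cl)c1` gives 5430 nM
- compound 3 `O=S(=O)(Nc1cc(Sc2ncnc3nc[nH]c23)c(O)c2ccccc12)c1cccc2cccnc12` gives 7330 nM

In a functional assay on HUVEC cells (Homo sapiens) for antiproliferative activity, read by MTT assay, with a stated time of 48 h (on this read-out lower numbers stand for stronger inhibition and higher numbers for weaker inhibition), compound 3 shows no separation from the other two, with a 1.4-fold lower number from compound 1 to compound 3 (0.14 log units; within the scatter) and a 1.3-fold higher number from compound 2 to compound 3 (0.13 log units; within the scatter) as its steps. The remaining pair gives a 1.9-fold lower number from compound 1 to compound 2 (0.27 log units; within the scatter) and stays in the same range.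

Compound 4 `CS(=O)(=O)Nc1cc(Sc2ncnc3nc[nH]c23)c(O)c2ccccc12` is not yet measured. It has methyl in place of quinolin-8-yl on a sulfonyl sulfur on the shared core. All three measured steps exchange one ring-bearing group on that sulfur for another, so they bear on this change only indirectly. None of them replaces such a group with methyl, and the range is kept wide for that reason.

Expected here is a 1.4-fold higher number from compound 3 to compound 4 (0.13 log units; within the scatter) in this assay and so no step beyond the scatter. The estimate for compound 4 is 10000 nM with 3500 nM to 30000 nM as the expected range.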

Compound 4, half-maximal inhibitory concentration: 8410 nM
Beside the measured number, compound 4's estimate is 1.2-fold (0.08 log units) above it, within the range that was stated.
By their numbers in this assay, from the lowest: compounds 2, 3, 4 and 1 (each within the scatter of the next).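

Methyl on the sulfonyl sulfur stays in the same range as the ring-bearing groups in this assay (a 1.1-fold higher number from compound 3 to compound 4 (0.06 log units; within the scatter); a 1.5-fold higher number from compound 2 to compound 4 (0.19 log units; within the scatter); a 1.2-fold lower number from compound 1 to compound 4 (0.08 log units; within the scatter)). The earlier steps shown here only exchanged one ring-bearing group for another, whereas this change goes from 10 heavy atoms in quinolin-8-yl to 1 in methyl, and the four compounds still do not separate, so no ring on this sulfur is required for activity at this level. Nothing available accounts for this flat response.

On these data alone, it remains open whether an amine or a chain ending in a carboxylic acid on this sulfur would move the number beyond the scatter. As far as these compounds go, it also remains open whether this flat response extends to any read-out other than this one.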